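Replacing a Ring Oxygen with Sulfur on the Sulfonyl Chain Carbon

The source may report more compounds than this note shows. Statements on the series, on what has been measured and on what is new or still open speak of the compounds shown alone.

Compound 1 `COc1ccc(C2=NN(c3ccccc3)C(c3ccc(C)cc3)C2S(=O)(=O)CC2=NCCO2)cc1` gives 59.1% in a functional assay, read by Griess assay, with a stated time of 150 min, tested at 50 ug/mL; on this read-out higher numbers stand for a stronger effect at the one concentration tested and lower numbers for a weaker effect. This is the highest of the two numbers recorded, but compound 3 `O=S(=O)(CC1=NCCO1)c1n[nH]cc1-c1ccccc1` gives 50.6% in this assay, a difference within the scatter, so the two are not separable. Compound 2 `O=S(=O)(CC1=NCCS1)c1c(-c2ccc(Cl)cc2)noc1-c1ccc(Cl)cc1` gives "not active" (no number reported) in this assay, with no number reported. Compound 4 `COc1ccc(C2=NN(c3ccccc3)C(c3ccc(C)cc3)C2S(=O)(=O)CC2=NCCS2)cc1` has not been measured; it differs from compound 1 by a group of 5 heavy atoms (3 carbon, 1 nitrogen, 1 sulfur; one five-membered non-aromatic ring with 2 hetero atoms) in place of a group of 5 heavy atoms (3 carbon, 1 nitrogen, 1 oxygen; one five-membered non-aromatic ring with 2 hetero atoms), on a saturated chain carbon bound to a sulfonyl sulfur. Among the compounds with values here, no pair among the measured compounds shares this change on a common core, so no step size can be drawn from the data. The step from compound 1 to compound 4 is expected to be about a number 9.1 percentage points lower from compound 1 to compound 4 (within the scatter), not beyond the scatter. Compound 4 is therefore estimated at 50%, between 25% and 70%.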

Compound 4, a percentage reported as activity, at one concentration (the size of the read-out at that concentration, not a potency): 39.4%
For compound 4 the middle estimate is 10.6 percentage points above the measured one, and the stated range covers the measured number.
By their numbers in this assay, from the lowest: compound 4; then compounds 3 and 1 (each within the scatter of the next).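

On the shared core, the exchange of the ring oxygen for sulfur gives a number 19.7 percentage points lower from compound 1 to compound 4 (beyond the scatter) in this assay. The group on the saturated chain carbon bound to a sulfonyl sulfur is therefore not interchangeable at this position, even though the two groups match in heavy-atom count, ring size, and hydrogen-bond donors and acceptors. Nothing available bears on the origin of this step.

From the compounds shown here alone, whether the same exchange gives a similar step on another core remains open. So does the result of an amine or a carboxylic acid on that chain carbon.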